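A few compounds are considered here, and "the series" means these few. Any claim that something is new, unique, unknown or untested is made for them only; others in the source may bear on it.

Measured compounds in the series:
compound 1 `CCO/N=C(/c1ccc(Br)cc1)C1CCN(C(C)CCNC(=O)c2c(Cl)cncc2Cl)CC1`: 33800 nM
compound 2 `CC(CCNC(=O)c1c(Cl)cncc1Cl)N1CCC(C(Oc2ncccc2Cl)c2ccc(C(F)(F)F)cc2)CC1`: 16700 nM
compound 3 `CCO/N=C(/c1ccc(Br)cc1)C1CCN(C(C)CCNC(=O)c2c(C)cc[n+]([O-])c2C)CC1`: a limit of the assay, > 177000 nM

In an ADME assay on PBMC cells (Homo sapiens) for cytotoxicity (a lower number here means that less compound is tolerated, a higher number that more compound is tolerated), compound 2 gives 16700 nM, the lowest of the two numbers; compound 1 gives 33800 nM. Compound 3 sits at the limit of the assay, > 177000 nM, so only a limit is known for it. Within the data shown here, the one measured step, an at least 5.2-fold higher number from compound 1 to compound 3 (0.71 log units; beyond the scatter), concerns the group on the carbonyl carbon and does not touch the change taken here.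

Compound 4 `CC(CCNC(=O)c1c(Cl)cncc1Cl)N1CCC(C(Oc2ccccc2)c2ccc(C(F)(F)F)cc2)CC1` differs from compound 2 by phenyl in place of 3-chloropyridin-2-yl on an oxygen on a saturated carbon. Among the measured compounds shown here, no measured step bears on this change, so in this assay no step beyond the scatter is expected; the expected step is a 1.2-fold higher number from compound 2 to compound 4 (0.08 log units; within the scatter). Compound 4 is therefore estimated at 20000 nM, with a range from 8000 nM to 50000 nM.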

Compound 4, half-maximal cytotoxic concentration: 6800 nM
Compound 4: the middle estimate sits 2.9-fold (0.47 log units) above what was measured; the measured number lies below the stated range.
By their numbers in this assay, from the lowest: compound 4; then compound 2; then compound 1. At a limit, above all of these: compound 3.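

In this assay, the group on the oxygen on a saturated carbon matters: with phenyl in place of 3-chloropyridin-2-yl, the result is a 2.5-fold lower number from compound 2 to compound 4 (0.39 log units; beyond the scatter), so less compound is tolerated. Among these compounds, this is the first reading at this position, as the earlier step concerned only the group on a carbonyl carbon. Nothing shown gives a cause for this step.

From the compounds shown here alone, the change removes the ring nitrogen and the chlorine together, so their shares in the step remain open. A 3-chlorophenyl or an unsubstituted pyridin-2-yl group on this oxygen would separate them.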